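The source may hold more compounds than are shown below. What is called first, only, known or untested is meant among the compounds shown, and "the series" means these compounds.

The series rests on a shared core, seen in compound 1 `COc1ccc(Oc2nc(Nc3ccc(C#N)cc3)nc3ccccc23)cc1` and compound 2 `Cc1cc(Br)c(Oc2nc(Nc3ccc(C#N)cc3)nc3ccccc23)c(Br)c1`, which differ only in the aryl group on an oxygen on an aromatic ring. In an ADME assay on MT4 cells (Homo sapiens) for cytotoxicity, read by MTT assay, with a stated time of 4 days (on this read-out higher numbers stand for lower toxicity in this test and lower numbers for higher toxicity in this test), compound 1 gives 340000 nM, while compound 2 gives 25000 nM. For the measured compounds named here, the single step measured so far is a 14-fold lower number from compound 1 to compound 2 (1.13 log units; beyond the scatter). Compound 2 therefore stands with the lowest of the two numbers, its nearest neighbour being compound 1 at a higher number.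

Compound 3 `Cc1ccccc1Oc1nc(Nc2ccc(C#N)cc2)nc2ccccc12` is the next compound to be read in this assay. Its change from compound 2 is 2-methylphenyl in place of 2,6-dibromo-4-methylphenyl on an oxygen on an aromatic ring. Going by the values given here, the only step that bears on it is the one from compound 1 to compound 2, in which the arrival of the 2,6-dibromo-4-methylphenyl group went with a large drop in the number; the present change removes that group again, so a move back in the opposite direction, upward, is expected, though the 2-methylphenyl group is not the 4-methoxyphenyl of compound 1 and the size of the return is uncertain. Compound 3 is expected to give about 150000 nM, in a range from 50000 nM to 400000 nM. This expectation corresponds to a step of a 6.0-fold higher number from compound 2 to compound 3 (0.78 log units; beyond the scatter).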

Compound 3, half-maximal cytotoxic concentration: 355000 nM
Compound 3: middle estimate off by 2.4-fold (0.37 log units), on the low side; low and high end bracket the measured number.
By their numbers in this assay, from the lowest: compound 2; then compounds 1 and 3 (each within the scatter of the next).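

In this assay the exchange of 2,6-dibromo-4-methylphenyl for 2-methylphenyl gives a 14-fold higher number from compound 2 to compound 3 (1.15 log units; beyond the scatter) and is large, so the low number of compound 2 goes with its 2,6-dibromo-4-methylphenyl group and does not extend to every aryl group tried on this oxygen. The other new comparison, a 1.0-fold higher number from compound 1 to compound 3 (0.02 log units; within the scatter), lies within the scatter, so 2-methylphenyl and 4-methoxyphenyl cannot be told apart on this read-out even though the two groups differ in their substituents. Among the three compounds, only the 2,6-dibromo-4-methylphenyl group stands apart in this test, and nothing available explains why it does so.

The compounds shown do not separate the contribution of the two bromine atoms from that of the rest of the 2,6-dibromo-4-methylphenyl group, and a single bromine or a chlorine on the aryl ring would be needed to tell these apart. They also leave open how this read-out would respond to an aryl group carrying an amine, a carboxylic acid or a chain longer than methyl.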